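Solubility notes: amine tail exchange on the shared core

The source may report more compounds than this note shows. Statements on the series, on what has been measured and on what is new or still open speak of the compounds shown alone.

Compound 1 `CC(C)c1ccc2c(c1)[n+]([O-])c(NCCN1CCCCC1)n[n+]2[O-]` and compound 2 `CCN(CC)CCNc1n[n+]([O-])c2ccc(C(C)(C)C)cc2[n+]1[O-]` carry the same core with different substitution. In a physicochemical assay for solubility, in the presence of a further agent that is not named here (on this read-out lower numbers stand for lower solubility and higher numbers for higher solubility), compound 1 gives 18000000 nM. Compound 2 reaches only a limit of this assay, > 48000000 nM, and thus stands at the limit of > 48000000 nM in this assay, at which 1 of the 2 values shown sits, without a definite number. Compound 3 `CC(C)(C)c1ccc2c(c1)[n+]([O-])c(NCCN1CCCCC1)n[n+]2[O-]` is not yet measured and differs from compound 2 by piperidin-1-yl in place of diethylamino on a saturated chain carbon, two bonds along the chain from a nitrogen on an aromatic ring. Among the measured compounds shown here, no measured step carries this change, so the expected step is small, downward or none beyond the scatter, as an at least 1.6-fold lower number from compound 2 to compound 3 (0.20 log units; that floor lies within the scatter). Compound 3 is expected near 30000000 nM, within 10000000 nM to 60000000 nM.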

Compound 3, solubility: 28000000 nM
Compound 3: the middle estimate sits 1.1-fold (0.03 log units) above what was measured; measured number inside the range.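

Piperidin-1-yl in place of diethylamino on a saturated chain carbon, two bonds along the chain from a nitrogen on an aromatic ring, now has a step in this assay, an at least 1.7-fold lower number from compound 2 to compound 3 (0.23 log units; that floor lies within the scatter), and only this floor can be read, since the value of compound 2 is a limit: the limit of > 48000000 nM in this assay, at which 1 of the 3 values shown sits.
Methyl in place of hydrogen on a saturated chain carbon bound to an aromatic carbon and two saturated chain carbons gives a 1.6-fold higher number from compound 1 to compound 3 (0.19 log units; within the scatter), so that change does not stand clear of the scatter.
Open, as far as these compounds go, is whether morpholin-4-yl or a carboxylic acid in the place of piperidin-1-yl, or a longer chain, would give a step beyond the scatter.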